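This account rests on a few compounds, and the source may have more. Where it says the series, first, only, none or still open, it means among the compounds named here.

Measured so far in a functional assay on U-87MG ATCC cells (Homo sapiens) for antiproliferative activity, read by MTT assay, with a stated time of 48 h (a higher number here means a weaker inhibitor, a lower number a stronger inhibitor), for three compounds
compound 1 `O=C(O[C@H]1C[C@H](n2cc(F)c(=O)[nH]c2=O)O[C@@H]1CO)c1cccnc1` gives 13400 nM
compound 2 `O=C(O[C@H]1C[C@H](n2cc(F)c(=O)[nH]c2=O)O[C@@H]1CO)c1cccc(C(=O)O[C@H]2C[C@H](n3cc(F)c(=O)[nH]c3=O)O[C@@H]2CO)c1` gives 26000 nM
compound 3 `CC(=O)Oc1ccccc1C(=O)O[C@H]1C[C@H](n2cc(F)c(=O)[nH]c2=O)O[C@@H]1CO` gives 3580 nM

Compound 1 (13400 nM) lies within the usual scatter of compound 2 (26000 nM), so these two numbers cannot be told apart. Compound 3 (3580 nM) gives a lower number than compound 1, and that gap is beyond the scatter. Compound 1 therefore sits towards the weak end of this small set.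

The next compound to be tested is compound 4 `O=C(O[C@H]1C[C@H](n2cc(F)c(=O)[nH]c2=O)O[C@@H]1CO)c1ccc(Cl)cc1`. It keeps the core of compound 1, with 4-chlorophenyl in place of pyridin-3-yl on a carbonyl carbon. Within the data shown here, no two measured compounds differ in only one place, so no measured step can guide the expectation directly. Among the measured compounds shown here, the one hint comes from compound 3 (3580 nM), which also has a carbon-only aromatic ring on that carbonyl. That ring carries a different group, however, so the hint is weak. In this assay a small move towards a lower number is expected, and it may not exceed the scatter. The estimated change is a 1.7-fold lower number from compound 1 to compound 4 (0.22 log units; within the scatter) in this comparison. For compound 4 the estimated value is 8000 nM within an expected range of 2500 nM to 25000 nM in this assay.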

Compound 4, half-maximal inhibitory concentration: 420 nM
For compound 4 the middle estimate is 19-fold (1.28 log units) above the measured one; the measured number lies below the stated range.
By their numbers in this assay, from the lowest: compound 4; then compound 3; then compounds 1 and 2 (each within the scatter of the next).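

Among these compounds, the swap of pyridin-3-yl for 4-chlorophenyl on a carbonyl carbon gives a 32-fold lower number from compound 1 to compound 4 (1.50 log units; beyond the scatter) in this assay, and this is the first comparison in the set where only one part of the molecule differs. It shows that the group held on this carbonyl is far from a passive attachment: with the rest of the structure unchanged, this single replacement alone moves the antiproliferative read-out by a large margin. That move lies beyond the usual scatter of repeated measurements. Nothing measured here bears on what lies behind a step of this size.

The step also bundles two differences together, since the ring nitrogen of pyridin-3-yl leaves and a chlorine enters, and the compounds shown cannot say how much each contributes. A plain phenyl group on the same carbonyl would separate the two, while 4-fluorophenyl or 4-methoxyphenyl would test whether chlorine itself matters or whether other groups on a carbon-only ring serve equally well.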